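Extending the acyl cap on the proline of compound 2

A few compounds are considered here, and "the series" means these few. Any claim that something is new, unique, unknown or untested is made for them only; others in the source may bear on it.

This account concerns a short series of legumain inhibitors that share one core and differ only in the group carried on a carbonyl carbon attached to the ring nitrogen. Within the data shown here, compound 2 `CCOC(=O)/C=C/C(=O)N(CC(N)=O)NC(=O)[C@@H]1CCCN1C(C)=O` gives 8.3 nM in an assay on isolated protein for inhibition of legumain (Mus musculus), read by fluorescence, with stated times of 30 s and 2.5 h (a lower number here means a stronger inhibitor, a higher number a weaker inhibitor), the lowest of the three numbers so far. Compound 3 `CCOC(=O)/C=C/C(=O)N(CC(N)=O)NC(=O)[C@@H]1CCCN1C(=O)C1(NC(C)=O)CC1` gives 9.3 nM, and compound 1 `CCOC(=O)/C=C/C(=O)N(CC(N)=O)NC(=O)[C@@H]1CCCN1C(=O)[C@H]1CSCN1C(C)=O` gives 167 nM.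

Two of the measured steps speak to what happens at this position. From compound 2 to compound 3 the change of methyl for 1-acetamidocyclopropyl produced a 1.1-fold higher number from compound 2 to compound 3 (0.05 log units; within the scatter), so a larger acetamido-bearing group in place of methyl left the number essentially unchanged. By contrast, a 20-fold lower number from compound 1 to compound 2 (1.30 log units; beyond the scatter) shows that one particular eight-atom group containing a five-membered ring with two hetero atoms gave a much weaker inhibitor than the simple methyl.

Compound 4 `C#CC[C@H](NC(C)=O)C(=O)N1CCC[C@H]1C(=O)NN(CC(N)=O)C(=O)/C=C/C(=O)OCC` is the next step from compound 2: a group of 8 heavy atoms (6 carbon, 1 nitrogen, 1 oxygen; no ring) in place of one carbon atom, on a carbonyl carbon. The entering group, like that of compound 3, carries an acetamide but, unlike that of compound 1, has no ring. Given the step from compound 2 to compound 3, the author expects little movement beyond the scatter in this assay, with a small risk of a weaker number. Compound 4 is therefore estimated at 12 nM in this assay, within a range of 4 nM to 40 nM, which corresponds to an expected step of a 1.4-fold higher number from compound 2 to compound 4 (0.16 log units; within the scatter).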

Compound 4, half-maximal inhibitory concentration: 17 nM
Compound 4: the middle estimate sits 1.4-fold (0.15 log units) below what was measured; measured number inside the range.
By their numbers in this assay, from the lowest: compounds 2, 3 and 4 (each within the scatter of the next, the first and the last beyond it); then compound 1.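

Compound 4 shows that this position, on a carbonyl carbon whose other neighbours are an amide-type nitrogen in a ring, also accepts a group with no ring that carries a triple bond and an acetamide: in this assay there is a 2.0-fold higher number from compound 2 to compound 4 (0.31 log units; beyond the scatter) as a modest cost against methyl, whereas the acetamide-bearing group of compound 3 showed no step beyond the scatter. The two larger acetamide-bearing groups cannot be told apart, with a 1.8-fold higher number from compound 3 to compound 4 (0.26 log units; within the scatter) in that comparison, while a 9.8-fold lower number from compound 1 to compound 4 (0.99 log units; beyond the scatter) between two entering groups of 8 heavy atoms each shows that the count of heavy atoms alone does not set the number here. No measurement at hand gives a reason for these differences.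

The compounds shown leave open whether the triple bond matters, as a plain propyl chain in its place would tell, and whether the acetamide matters, as a free amine would tell. They also leave open how the defined stereocentre of the entering group bears on the number, and how a carboxylic acid on a longer chain would fare at this position.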